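Thiosemicarbazone Cytotoxicity: Chloro for Iodo at Two Places

The source may hold more compounds than are shown below. What is called first, only, known or untested is meant among the compounds shown, and "the series" means these compounds.

Measured compounds:
Compound 1, `C/C(=N\NC(=S)Nc1ccccc1I)c1ccccn1`, 6.1 nM
Compound 2, `C/C(=N\NC(=S)Nc1ccccc1Cl)c1ccccn1`, 2.6 nM
Compound 3, `CC(=NNC(=S)Nc1ccc(I)cc1)c1ccccn1`, 59 nM

In a functional assay on U-87MG ATCC cells (Homo sapiens) for cytotoxicity, read by MTT assay, with a stated time of 48 h (a lower number here means a stronger inhibitor, a higher number a weaker inhibitor), compound 1 gives 6.1 nM. Compound 2 is its close relative, differing by chloro in place of iodo on an aromatic carbon, and compound 2 gives 2.6 nM; the step of a 2.3-fold lower number from compound 1 to compound 2 (0.37 log units; beyond the scatter). Compound 3 has the same atoms as compound 1 joined differently, and the difference between the two cores is not broken down here. In this assay compound 3 gives 59 nM, the highest of the three numbers, beyond the scatter from both compound 1 and compound 2.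

Compound 4, `CC(=NNC(=S)Nc1ccc(Cl)cc1)c1ccccn1`, has not yet been measured in this assay. It differs from compound 3 by chloro in place of iodo on an aromatic carbon. Among the compounds with values here, this is the same kind of change as the one from compound 1 to compound 2, not the same: in the earlier pair the place is ortho to a large group, in this pair it is para to a large group. Within the data shown here, the only guidance is the single measured step of a 2.3-fold lower number from compound 1 to compound 2 (0.37 log units; beyond the scatter), so for compound 4 the expected step is a 2.1-fold lower number from compound 3 to compound 4 (0.32 log units; beyond the scatter), with a wider range because the place differs. Compound 4 is expected to give 28 nM, between 10 nM and 80 nM.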

Compound 4, half-maximal inhibitory concentration: 1.7 nM
Estimate against measurement, compound 4: 16-fold (1.22 log units) above, outside the stated range (below it).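

The iodo-to-chloro change did not carry over from one core to the other with a constant size in this assay: the same change on two cores in this assay, a 2.3-fold lower number (0.37 log units; beyond the scatter) from compound 1 to compound 2 and a 35-fold lower number (1.54 log units; beyond the scatter) from compound 3 to compound 4, 15-fold (1.17 log units) apart, beyond the scatter of two such steps

The new pair gives a 35-fold lower number from compound 3 to compound 4 (1.54 log units; beyond the scatter), so the chloro compound has the lower number in both pairs, but a step measured on one core proved a poor guide to the size of the step on the other. This does not show why the two steps differ: the change in the new pair sits para to a large group, at a different place from the earlier pair, and two pairs cannot separate an effect of that place from any other difference between the cores.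

With only iodo and chloro among the compounds shown, it remains open whether a bromo, a methoxy or an amine on the same aromatic carbon would give numbers that follow the same direction on both cores. From the compounds shown here alone, it also remains open whether the direction seen in these two pairs would hold for the same change on any further core, since two pairs are all that can be compared here.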